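Allyl to Hydrogen on the Core Nitrogen of Compound 1

The source may hold more compounds than are shown below. What is called first, only, known or untested is meant among the compounds shown, and "the series" means these compounds.

Measured compounds:
compound 1, `C=CCn1c(=O)n(C(=O)NCCN2CCN(C)CC2)c2ccccc21` — > 1000 nM
compound 2, `CC(C)n1c(=O)n(C(=O)NN2CCN(C)CC2)c2ccccc21` — > 1000 nM
compound 3, `CC(C)n1c(=O)n(C(=O)NCCN2CCN(C)CC2)c2cc(F)c(N)cc21` — > 1000 nM

In an assay on isolated protein for displacement of a labelled ligand from 5-hydroxytryptamine receptor 4 (Cavia porcellus) (on this read-out lower numbers stand for stronger inhibition and higher numbers for weaker inhibition), compound 1 gives > 1000 nM, which is a limit of the assay and not a number. Compound 2 also stops at a limit, > 1000 nM. Compound 3 likewise gives only a limit, > 1000 nM. Compound 1 therefore stands nowhere in particular among the three: every result shown is the limit of > 1000 nM in this assay, at which 3 of the 3 values shown sit, so no ordering can be drawn and no step between any two of them can be sized.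

Compound 4, `CN1CCN(CCNC(=O)n2c(=O)[nH]c3ccccc32)CC1`, has not yet been measured. It differs from compound 1 by hydrogen in place of allyl on an aromatic nitrogen, in words hydrogen in place of allyl on an aromatic nitrogen. Going by the values given here, no measured pair shows what such a change does here, and because the three known values all sit at the limit of > 1000 nM in this assay, at which 3 of the 3 values shown sit, there is no number from which a step could start. The expectation is that compound 4 stays near the same limit, with no change beyond the scatter; the step that the limit leaves unreadable from compound 1 to compound 4 is what this estimate means. Compound 4 is estimated at 3000 nM, expected between 800 nM and 20000 nM.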

Compound 4, half-maximal inhibitory concentration: 1000 nM
Compound 4: the middle estimate sits 3.0-fold (0.48 log units) above what was measured, and the stated range covers the measured number.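

Going by these compounds alone, with hydrogen in place of allyl on the aromatic nitrogen, compound 4 gives the only true number of the set in this assay, 1000 nM. Compound 1 gives > 1000 nM, which is a limit of the assay and not a number. The step is a number no higher from compound 1 to compound 4 (the limit leaves the size open) with hydrogen in place of allyl. This shows that the position can carry hydrogen and still return a value inside the range of the assay, yet the size of the change from allyl to hydrogen cannot be read, for this reason: the limit of > 1000 nM in this assay, at which 3 of the 4 values shown sit.

The compounds shown leave open whether a methyl group, a benzyl group or a longer alkyl chain on this nitrogen would give a value different from that of compound 4. They also leave open how hydrogen here would act alongside an amine on the benzene-side ring positions of the shared core.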